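Swapping carboxy for hydrogen on compound 1

This account rests on a few compounds, and the source may have more. Where it says the series, first, only, none or still open, it means among the compounds named here.

Measured so far in an ADME assay for permeability, using PAMPA, at pH 7.4 (a higher number here means that the compound crosses the layer faster, a lower number that the compound crosses the layer more slowly), are two compounds:
- compound 1 `Cc1ccc(-c2nc3ccccc3s2)cc1NC(=O)c1cc([N+](=O)[O-])c(N2CCC(C(=O)O)CC2)cc1Cl` (17 10^-6 cm/s)
- compound 2 `O=C(Nc1nc2ccc(F)cc2s1)c1cc([N+](=O)[O-])ccc1Cl` (10 10^-6 cm/s)

Going by the values given here, compound 1 (17 10^-6 cm/s) stands within the scatter of compound 2 (10 10^-6 cm/s), the only other number available. Compound 3 `Cc1ccc(-c2nc3ccccc3s2)cc1NC(=O)c1cc([N+](=O)[O-])c(N2CCCCC2)cc1Cl` differs from compound 1 at one place hydrogen in place of carboxy on a saturated ring carbon and has hydrogen in place of carboxy on a saturated ring carbon. Among the compounds with values here, no measured pair shows this change, so the expectation is uncertain, and no step beyond the scatter is expected in this assay for now. The estimated step is small (a 1.1-fold lower number from compound 1 to compound 3 (0.05 log units; within the scatter)). Compound 3 is estimated at 15 10^-6 cm/s with an expected range of (4 10^-6 cm/s to 40 10^-6 cm/s).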

Compound 3, apparent permeability: < 1 10^-6 cm/s
Compound 3 ended at the assay's limit; the forecaster's own chance of this, stated with the estimate: 10%; at least 15-fold (1.17 log units) between middle value and limit.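

In this assay, going by these compounds alone, the earlier compounds gave no step at this place, and the first one is large: going from 4-carboxypiperidin-1-yl to piperidin-1-yl, with the rest of the molecule unchanged, gives an at least 17-fold lower number from compound 1 to compound 3 (1.23 log units; beyond the scatter). Compound 3 gives < 1 10^-6 cm/s, which is a limit of the assay and not a number. The step is therefore a bound and not a size: the limit of < 1 10^-6 cm/s in this assay, at which 1 of the 3 values shown sits.

On these data alone, whether a methyl ester, a hydroxyl or an amine on that saturated ring carbon would stand with compound 1 or with compound 3 in this assay remains open. So does whether the same change acts alike on another core.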